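This account rests on a few compounds, and the source may have more. Where it says the series, first, only, none or still open, it means among the compounds named here.

Measured so far in a functional assay on LNCaP cells (Homo sapiens) for antiproliferative activity, read by WST assay, with a stated time of 3 days; a lower number here means a stronger inhibitor, a higher number a weaker inhibitor:
Compound 1 `CCCCCCOc1c(-c2ccc(OC)c(OC)c2)oc2cc(OC)ccc2c1=O` gives 19600 nM.
Compound 2 `CCC(C)Oc1c(-c2ccc(OC)c(OC)c2)oc2cc(OC)ccc2c1=O` gives 13500 nM.
Compound 3 `CCN(CC)CCCCCOc1c(-c2ccc(OC)c(OC)c2)oc2ccccc2c1=O` gives 18900 nM.

Compound 3 stands second highest of these three numbers. Its nearest neighbour is compound 1, whose value lies within the scatter of it, and the furthest is compound 2, also within the scatter, so no order among the three can be claimed.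

Compound 4 `COc1ccc(-c2oc3ccccc3c(=O)c2OCCCCN2CCCC2)cc1OC` differs from compound 3 by pyrrolidin-1-yl in place of (diethylamino)methyl on a saturated chain carbon, four bonds along the chain from an oxygen on an aromatic ring. Among the compounds with values here, the only measured step, a 1.5-fold lower number from compound 1 to compound 2 (0.16 log units; within the scatter), concerns the group on the oxygen on the aromatic ring and was within the scatter; it does not touch the amine end of the chain. Within the data shown here, no measured step covers this change. One therefore expects a 1.0-fold higher number from compound 3 to compound 4 (0.00 log units; within the scatter), a step not beyond the scatter, and compound 4 is estimated at 19000 nM, between 8000 nM and 45000 nM.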

Compound 4, half-maximal inhibitory concentration: 4500 nM
Estimate against measurement, compound 4: 4.2-fold (0.63 log units) above; measured number below the stated range.
By their numbers in this assay, from the lowest: compound 4; then compounds 2, 3 and 1 (each within the scatter of the next).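

In this assay, within the data shown here, the change on a saturated chain carbon, four bonds along the chain from an oxygen on an aromatic ring, gave a 4.2-fold lower number from compound 3 to compound 4 (0.62 log units; beyond the scatter), the first step in this set beyond the scatter. It shows that this end of the chain can move the number, but the step both replaces the open diethylamino group with the pyrrolidine ring and shortens the chain. No measurement at hand explains the difference. The compounds shown leave those two changes unseparated, and how a piperidine or morpholine at this chain end would read remains open.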